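A few compounds are considered here, and "the series" means these few. Any claim that something is new, unique, unknown or untested is made for them only; others in the source may bear on it.

For the measured compounds named here, only two compounds have been measured so far in a physicochemical assay for lipophilicity; on this read-out higher numbers stand for higher lipophilicity and lower numbers for lower lipophilicity. Compound 1 (`CC(C)(O)C(=O)Nc1ccc(Cl)cc1`) gives 2. Compound 2 (`CC(C(=O)Nc1ccc([N+](=O)[O-])c(C(F)(F)F)c1)C(F)(F)F`) gives 3.71, the higher of the two numbers, and the gap between them lies beyond the scatter. Compound 3 (`CC(O)(CF)C(=O)Nc1ccc([N+](=O)[O-])c(C(F)(F)F)c1`) has not been measured yet. It differs from compound 2 at one place, on a carbonyl carbon, where 1-(fluoromethyl)-1-hydroxyethyl stands in place of 1-(trifluoromethyl)ethyl: 1-(fluoromethyl)-1-hydroxyethyl in place of 1-(trifluoromethyl)ethyl on a carbonyl carbon. Going by the values given here, no measured pair shows this exchange, so the evidence for a forecast is thin. Among the compounds with values here, the only guide is compound 1, which also has a hydroxy group and reads 2. A clear fall beyond the scatter is therefore expected, with an estimated a number 1.21 log units lower from compound 2 to compound 3 (beyond the scatter). In this assay, compound 3 is expected to read 2.5, with an estimated range of 2 to 3.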

Compound 3, partition coefficient: 3.5
Estimate against measurement, compound 3: 1.00 log units below; measured number above the stated range.
By their numbers in this assay, from the lowest: compound 1; then compounds 3 and 2 (each within the scatter of the next).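

In this assay, for the compounds shown here, the exchange of 1-(trifluoromethyl)ethyl for 1-(fluoromethyl)-1-hydroxyethyl on a carbonyl carbon gives a number 0.21 log units lower from compound 2 to compound 3 (within the scatter), the first reading of any change at this place. The entering group brings one hydrogen-bond donor and one hydrogen-bond acceptor, and this read-out still stays within the usual scatter, so on this core a hydroxy-bearing group here can match 1-(trifluoromethyl)ethyl. Nothing available accounts for this result.

On these data alone, the exchange alters the hydroxy group and the fluorine content together, so the contribution of each to the reading stays open. Also open, as far as these compounds go, is how this assay would respond to an amine or a carboxylic acid on this same carbonyl carbon, and whether the match seen between compound 2 and compound 3 would hold on another core.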